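Series notes: substituted piperidine returned at the ring nitrogen

The source may report more compounds than this note shows. Statements on the series, on what has been measured and on what is new or still open speak of the compounds shown alone.

Three measured compounds share one core: compound 1 `CN1CCN(c2ccc(Nc3ncc4nc(Nc5ccc(F)cc5)n([C@H]5CCCN(S(=O)(=O)C6CC6)C5)c4n3)cc2)CC1`, compound 2 `CC(=O)Nc1cccc(-n2c(Nc3ccc(F)cc3)nc3cnc(Nc4ccc(N5CCN(C)CC5)cc4)nc32)c1` and compound 3 `CN1CCN(c2ccc(Nc3ncc4nc(Nc5ccc(F)cc5)n([C@@H]5CCNC5)c4n3)cc2)CC1`. In a functional assay on HCC827 cells (Homo sapiens) for antiproliferative activity, read by MTT assay, with a stated time of 72 h (a lower number here means a stronger inhibitor, a higher number a weaker inhibitor), compound 1 gives 8.6 nM, compound 2 gives 10 nM and compound 3 gives 300 nM, the highest number of the three; the steps of a 35-fold higher number from compound 1 to compound 3 (1.54 log units; beyond the scatter) and a 30-fold higher number from compound 2 to compound 3 (1.48 log units; beyond the scatter) are both large, whereas a 1.2-fold higher number from compound 1 to compound 2 (0.07 log units; within the scatter) is not. Compound 4 `CN1CCN(c2ccc(Nc3ncc4nc(Nc5ccc(F)cc5)n([C@@H]5CCCN(C(=O)CO)C5)c4n3)cc2)CC1` is not yet measured; its change from compound 3 is 1-((hydroxymethyl)carbonyl)piperidin-3-yl in place of pyrrolidin-3-yl on an aromatic nitrogen. This restores a six-membered ring carrying a group on its nitrogen, an arrangement resembling compound 1, so the two large steps are the ones that bear on it and a large drop in the number is expected, a 20-fold lower number from compound 3 to compound 4 (1.30 log units; beyond the scatter). Compound 4 is therefore estimated at 15 nM, within 5 nM to 60 nM in this assay.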

Compound 4, half-maximal inhibitory concentration: 66 nM
The estimate for compound 4 lay 4.4-fold (0.64 log units) below the measured number; the measured number lies above the stated range.
By their numbers in this assay, from the lowest: compounds 1 and 2 (each within the scatter of the next); then compound 4; then compound 3.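

In this assay a piperidine carrying 1-((hydroxymethyl)carbonyl) recovers only part of what is lost with pyrrolidin-3-yl, with a 4.5-fold lower number from compound 3 to compound 4 (0.66 log units; beyond the scatter) as the gain. A six-membered ring with a group on its nitrogen does not by itself reach the level of the other two: a 7.7-fold higher number from compound 1 to compound 4 (0.89 log units; beyond the scatter) against 1-(cyclopropylsulfonyl)piperidin-3-yl and a 6.6-fold higher number from compound 2 to compound 4 (0.82 log units; beyond the scatter) against 3-acetamidophenyl remain. No evidence on the origin of these differences is available.

A free piperidin-3-yl amine and 1-acetylpiperidin-3-yl would separate ring size from the hydroxyl-bearing acyl group. Going by these compounds, compound 1 and compound 4 also have opposite written stereocentres, so the share of configuration stays open.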